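Aryl in place of methyl on the carbonyl carbon

A few compounds are considered here, and "the series" means these few. Any claim that something is new, unique, unknown or untested is made for them only; others in the source may bear on it.

Compound 1 `CC(=O)N1N=C(c2ccc(N3CCN(C)CC3)cc2)CC1c1ccc(N(C)C)cc1`: -0.8%
Compound 2 `CN1CCN(c2ccc(C3=NN(C(=O)c4ccc(C(F)(F)F)cc4)C(c4ccc(N(C)C)cc4)C3)cc2)CC1`: 84.1%
Compound 3 `CC(=O)N1N=C(c2ccc(-n3cncn3)cc2)CC1c1ccc(N(C)C)cc1`: 11%

In a functional assay on HCC1806 cells (Homo sapiens) for inhibition, read by sulforhodamine B assay, tested at 10 uM (a lower number here means less inhibition, a higher number more inhibition at the concentration tested (going by the name of the read-out)), compound 3 stands second highest of the three numbers; the step to compound 2 is large, the step from compound 1 is modest, both beyond the scatter. Compound 4 `CN(C)c1ccc(C2CC(c3ccc(-n4cncn4)cc3)=NN2C(=O)c2cc(Cl)cc(Cl)c2)cc1` differs from compound 3 by 3,5-dichlorophenyl in place of methyl on a carbonyl carbon. The measured step that bears on this is a number 84.9 percentage points higher from compound 1 to compound 2 (beyond the scatter), the same kind of exchange on the same carbonyl carbon. The other step, a number 11.8 percentage points higher from compound 1 to compound 3 (beyond the scatter), concerns the aromatic carbon and is not directly comparable. A large rise is therefore expected, a number 64 percentage points higher from compound 3 to compound 4 (beyond the scatter). Compound 4 is estimated at 75%, with a range from 45% to 95%.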

Compound 4, a percentage reported as inhibition, at one concentration (the size of the read-out at that concentration, not a potency): 5.3%
Estimate against measurement, compound 4: 69.7 percentage points above, and the stated range ends above it.
By their numbers in this assay, from the lowest: compounds 1, 4 and 3 (each within the scatter of the next, the first and the last beyond it); then compound 2.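

In this assay the exchange of methyl for 3,5-dichlorophenyl on the carbonyl carbon reads a number 5.7 percentage points lower from compound 3 to compound 4 (within the scatter) and so an aryl group at this position does not by itself bring the rise of a number 84.9 percentage points higher from compound 1 to compound 2 (beyond the scatter) in this series. The two steps differ both in the aryl group and in the 1H-1,2,4-triazol-1-yl of compound 4 against the 4-methylpiperazin-1-yl of compound 2, and either difference could decide the outcome. No evidence bears on what lies behind this result.

Open, from the compounds shown here alone, is whether 4-(trifluoromethyl)phenyl keeps its gain alongside 1H-1,2,4-triazol-1-yl, and whether 3,5-dichlorophenyl gains alongside 4-methylpiperazin-1-yl. Also open, going by these compounds, is how a benzyl group or a longer alkyl chain behaves on this carbonyl carbon.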